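Swapping the Aryl Ether for a Thioether in Compound 4

The source may hold more compounds than are shown below. What is called first, only, known or untested is meant among the compounds shown, and "the series" means these compounds.

Compound 1 `CCOC(=O)[C@H](CCC(=O)O)NC(=O)c1ccc(Sc2nc3cc(N)cc(N)c3nc2-c2ccccc2)cc1`: < 100000 nM
Compound 2 `Nc1cc(N)c2nc(-c3ccccc3)c(Oc3ccc(F)cc3)nc2c1`: < 100000 nM
Compound 3 `COc1ccc(CNc2nc3cc(N)cc(N)c3nc2-c2ccccc2)cc1`: 26900 nM

Of the compounds shown here, three have been measured in a functional assay on IGROV-1 cells (Homo sapiens) for inhibition, read by sulforhodamine B assay, with a stated time of 48 h; on this read-out lower numbers stand for stronger inhibition of growth and higher numbers for weaker inhibition of growth. For compound 1 the result is only a limit of the assay, < 100000 nM. For compound 2 as well the result is only a limit, < 100000 nM. Compound 3 gives a number, 26900 nM. Compound 2 therefore stands at the limit of < 100000 nM in this assay, at which 2 of the 3 values shown sit, not at a number. Compound 4 `COc1ccc(Sc2nc3cc(N)cc(N)c3nc2-c2ccccc2)cc1` has not yet been measured; it differs from compound 2 in (4-methoxyphenyl)sulfanyl in place of 4-fluorophenoxy on an aromatic carbon. Within the data shown here, no step between two measured compounds is known, so neither size nor direction of the step in this assay can be read from the data. Compound 4 is expected to give 20000 nM (range 5000 nM to 80000 nM). This estimate would mean a step that the limit leaves unreadable from compound 2 to compound 4.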

Compound 4, concentration for total growth inhibition: < 100000 nM
Compound 4: no number, only a limit; the forecaster's own chance of this, stated with the estimate: 35%; the middle value does not contradict the limit.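

Compound 2 and compound 4 each give only a limit of the assay, and the step between them cannot be read. The compounds shown leave open whether (4-methoxyphenyl)sulfanyl in place of 4-fluorophenoxy changes growth inhibition at all.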